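A few compounds are considered here, and "the series" means these few. Any claim that something is new, unique, unknown or untested is made for them only; others in the source may bear on it.

Measured compounds:
- compound 1, `O=C(Nc1ccnnc1)c1cc(N2CCNCC2)ccc1OCc1ccccc1`, gives 1.9 in a physicochemical assay for lipophilicity, at pH 7.4; a higher number here means a more lipophilic compound, a lower number a more polar compound
- compound 2, `O=C(Nc1ccnnc1)c1cc(N2CCCC2)ccc1OCc1ccccc1`, gives 6.1 in this assay
- compound 3, `O=C(Nc1ccnnc1)c1cc(N2CCC(CO)CC2)ccc1OCc1ccccc1`, gives 3.5 in this assay

Compound 3 holds the second highest of the three numbers in this assay: it sits a number 1.60 log units higher from compound 1 to compound 3 (beyond the scatter) and a number 2.60 log units lower from compound 2 to compound 3 (beyond the scatter), so it lies nearer to compound 1 than to compound 2. All three compounds share the same core and differ only in the ring attached to one aromatic carbon, and every swap of that ring so far has moved the number well beyond the scatter, the largest being a number 4.20 log units higher from compound 1 to compound 2 (beyond the scatter).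

Compound 4, `CN1CC2(CCN(c3ccc(OCc4ccccc4)c(C(=O)Nc4ccnnc4)c3)CC2)C1`, takes the same route: a group of 10 heavy atoms (8 carbon, 2 nitrogen; one four-membered non-aromatic ring with 1 hetero atom, one six-membered non-aromatic ring with 1 hetero atom) in place of a group of 8 heavy atoms (6 carbon, 1 nitrogen, 1 oxygen; one six-membered non-aromatic ring with 1 hetero atom), on an aromatic carbon. Among the measured compounds shown here, no measured step matches this exact exchange. The nearest comparison is compound 1, whose ring at this position also carries a second nitrogen and which gives 1.9, the lowest number in the set. Compound 4, with no hydrogen-bond donor left in the entering group but two nitrogens in it, is therefore expected to land between compound 1 and compound 3, with an expected step of a number 1.00 log units lower from compound 3 to compound 4 (beyond the scatter). The estimate for compound 4 in this assay is 2.5, with a likely range from 1.2 to 3.8.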

Compound 4, distribution coefficient: 2.2
For compound 4 the middle estimate is 0.30 log units above the measured one; the range from low to high includes it.
By their numbers in this assay, from the lowest: compounds 1 and 4 (each within the scatter of the next); then compound 3; then compound 2.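

In this assay, among the compounds shown here, the entering group of compound 4 is the largest at this position so far, with 10 heavy atoms and no hydrogen-bond donor, yet it gives a lower number than the 4-(hydroxymethyl)piperidin-1-yl group with 8 heavy atoms (a number 1.30 log units lower from compound 3 to compound 4 (beyond the scatter)) and the pyrrolidin-1-yl group (a number 3.90 log units lower from compound 2 to compound 4 (beyond the scatter)). Adding heavy atoms and removing the hydrogen-bond donor therefore do not by themselves raise the number at this aromatic carbon, and compound 4 now stands level with the smaller piperazin-1-yl compound, as both groups hold 2 nitrogens (a number 0.30 log units higher from compound 1 to compound 4 (within the scatter)). Nothing available explains this match, so the shared nitrogen count remains an observation and not a cause.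

The compounds shown leave open how much of the low number comes from the second nitrogen, since the groups in compound 1 and compound 4 also differ in size and ring pattern. A morpholin-4-yl group, with oxygen as its second ring hetero atom, or a spiro group of the same shape with its nitrogen replaced by carbon would put that question to a direct test.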